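Triazolylmethyl aryl swap on the spiro-oxindole series

The compounds below may be only part of what the source reports. "The series", "measured", "known", "first", "only" and "open" are said of these compounds alone.

The series centres on the spiro-oxindole core of compound 2 `N#CC1=C(N)Oc2c(N)cc3nc4ccccc4nc3c2C12C(=O)N(Cc1cnnn1-c1cccc(Br)c1)c1ccccc12`, carrying a triazole whose aromatic nitrogen bears an aryl group. Among the compounds with values here, in a functional assay on HCT-116 cells (Homo sapiens) for antiproliferative activity, read by MTT assay, with a stated time of 48 h (a higher number here means a weaker inhibitor, a lower number a stronger inhibitor), compound 2 gives 26100 nM, the only numerical value in hand. Compound 1 `COc1ccccc1-n1nncc1CN1C(=O)C2(C(C#N)=C(N)Oc3c2c2nc4ccccc4nc2c2ccccc32)c2ccccc21`, a different core bearing a 2-methoxyphenyl on the triazole, reaches only the limit of this assay, > 50000 nM; this is a limit and not a number, and it marks the ceiling the limit of > 50000 nM in this assay, at which 1 of the 2 values shown sits, at which one of the two results sits. Compound 3 `Cc1ccc(-n2nncc2CN2C(=O)C3(C(C#N)=C(N)Oc4c(N)cc5nc6ccccc6nc5c43)c3ccccc32)cc1Cl` keeps the core of compound 2 and changes only the aryl on the triazole: 3-chloro-4-methylphenyl in place of 3-bromophenyl on an aromatic nitrogen. Within the data shown here, no step between measured compounds isolates this kind of change, so there is nothing to calibrate against. With two halogenated aryl groups of matching size and no change in donors or acceptors, a step from compound 2 to compound 3 of a 1.0-fold lower number from compound 2 to compound 3 (0.02 log units; within the scatter) is expected in this assay, within the scatter. Compound 3 is therefore estimated at 25000 nM, between 8000 nM and 80000 nM, with a real chance that only a limit is returned.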

Compound 3, half-maximal inhibitory concentration: > 50000 nM
Compound 3: a limit, no number (the forecaster's own chance of this, stated with the estimate: 30%); middle value at least 2.0-fold (0.30 log units) from the limit.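

In this assay, within the data shown here, the swap to 3-chloro-4-methylphenyl from 3-bromophenyl on the aromatic nitrogen gives an at least 1.9-fold higher number from compound 2 to compound 3 (0.28 log units; that floor lies within the scatter) as the first step that differs in one place. On these data alone, compound 3 returns a limit and not a number, so this step is only a floor and its true size stays unknown. This change gives no sign of a stronger compound, and the ceiling now holds most of the set: the limit of > 50000 nM in this assay, at which 2 of the 3 values shown sit.

As far as these compounds go, whether a pyridyl or a benzyl group on this nitrogen would bring the number down, and how far a bare phenyl would stand from 3-bromophenyl, remain open. Compound 1 differs from compound 2 in more than one place, so the 2-methoxyphenyl group cannot be read on its own.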